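A few compounds are considered here, and "the series" means these few. Any claim that something is new, unique, unknown or untested is made for them only; others in the source may bear on it.

Compounds 1 and 2 set the baseline of the series: compound 1 `CC(C)(C)Cc1c(-c2ccc(F)cc2F)sc(N)c1C(=O)c1ccc(Cl)cc1` gives 1% in an assay on CHO cells for displacement of a labelled ligand from adenosine receptor A1 (Homo sapiens), read by scintillation counting, tested at 10 uM (on this read-out higher numbers stand for more inhibition at the one concentration tested (going by the name of the read-out) and lower numbers for less inhibition), and compound 2 `CC(C)(C)Cc1c(-c2c(F)cccc2F)sc(N)c1C(=O)c1ccc(Cl)cc1` gives 1%. Compound 3 `COc1ccccc1-c1sc(N)c(C(=O)c2ccc(Cl)cc2)c1CC(C)(C)C` gives 1% and so stands level with compounds 1 and 2 at the digits shown; the steps of no change at the digits printed from compound 1 to compound 2 (within the scatter), no change at the digits printed from compound 1 to compound 3 (within the scatter) and no change at the digits printed from compound 2 to compound 3 (within the scatter) are all within the scatter, so the three aromatic replacements tried so far left the read-out where it was.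

Compound 4 `CC(C)(C)Cc1c(Br)sc(N)c1C(=O)c1ccc(Cl)cc1` has not been measured. Its difference from compound 3 is bromo in place of 2-methoxyphenyl on an aromatic carbon. Going by the values given here, none of the measured steps swaps the whole 2-methoxyphenyl, 2,4-difluorophenyl or 2,6-difluorophenyl group for bromo, so no step bears on this change directly; the only guide is that every change at this aromatic carbon so far, no change at the digits printed from compound 1 to compound 3 (within the scatter) among them, stayed within the scatter, and that compounds 1 to 3 all sit at the bottom of the read-out. Compound 4 is therefore expected to give a step of a number 1 percentage points higher from compound 3 to compound 4 (within the scatter) no larger than the scatter. The estimate for compound 4 is 2%, with a range from -8% to 15%.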

Compound 4, a percentage reported as inhibition, at one concentration (the size of the read-out at that concentration, not a potency): 1%
For compound 4 the middle estimate is 1 percentage points above the measured one; the measured number falls inside the stated range.
By their numbers in this assay, from the lowest: compounds 1, 2, 3 and 4 (each within the scatter of the next).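

In this assay, bromo in place of 2-methoxyphenyl gives no change at the digits printed from compound 3 to compound 4 (within the scatter), while bromo in place of the difluorophenyl groups gives no change at the digits printed from compound 2 to compound 4 (within the scatter) and no change at the digits printed from compound 1 to compound 4 (within the scatter). The earlier compounds shown here varied only the groups on a six-membered aromatic ring, whereas compound 4 has no such ring at this carbon next to the ring sulfur, and a single bromine atom in place of the 8 heavy atoms of 2-methoxyphenyl still leaves the read-out at the bottom of its range. Nothing available accounts for this flat result.

On these data alone, it remains open whether an amine, a carboxylic acid or a longer chain at this carbon would move the read-out above the level of these four compounds. Also open, as far as these compounds go, is whether any change to the neopentyl, amino or (4-chlorophenyl)carbonyl groups, which all four compounds share, would do so.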